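Moving the chlorine around the benzyl ring

This account rests on a few compounds, and the source may have more. Where it says the series, first, only, none or still open, it means among the compounds named here.

Among the compounds with values here, compound 3 `Cc1cc(-c2ccccc2)n(/C(N)=N/S(=O)(=O)c2cc(C)c(Cl)cc2SCc2ccc(Cl)cc2)n1` has the lowest number among the three compounds measured so far: in a functional assay on HeLa cells (Homo sapiens) for cytotoxicity, read by MTT assay, with a stated time of 72 h (on this read-out lower numbers stand for stronger inhibition and higher numbers for weaker inhibition), compound 3 gives 3000 nM. The nearest of the others is compound 2 `Cc1cc(-c2ccccc2)n(/C(N)=N/S(=O)(=O)c2cc(C)c(Cl)cc2SCc2cccc(Cl)c2)n1`, which in this assay gives 8000 nM. The step of a 2.7-fold lower number from compound 2 to compound 3 (0.43 log units; beyond the scatter) goes with a single change, 3-chlorophenyl becoming 4-chlorophenyl on the saturated chain carbon bound to a sulfur. Furthest away is compound 1 `Cc1ccc(CSc2cc(Cl)c(C)cc2S(=O)(=O)/N=C(\N)n2nc(C)cc2-c2ccccc2)cc1`, which in this assay gives 62000 nM. The step of a 21-fold lower number from compound 1 to compound 3 (1.32 log units; beyond the scatter) replaces a methyl with a chlorine on that aromatic ring, and the step of a 7.8-fold lower number from compound 1 to compound 2 (0.89 log units; beyond the scatter) swaps 4-methylphenyl for 3-chlorophenyl.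

Compound 4 `Cc1cc(-c2ccccc2)n(/C(N)=N/S(=O)(=O)c2cc(C)c(Cl)cc2SCc2ccccc2Cl)n1` is not yet measured. It differs from compound 3 in one place: 2-chlorophenyl in place of 4-chlorophenyl on a saturated chain carbon bound to a sulfur. The step that bears most directly on this, a 2.7-fold lower number from compound 2 to compound 3 (0.43 log units; beyond the scatter), likewise moved the chlorine between two ring positions and was modest in size. Within the data shown here, a chlorine on the benzyl ring has so far given lower numbers than a methyl there, but only one pair of chlorine positions has been compared, so the direction for 2-chlorophenyl is uncertain and a modest step either way is plausible. The expectation for compound 4 is a slight weakening, a step of a 1.7-fold higher number from compound 3 to compound 4 (0.22 log units; within the scatter) in this assay. Compound 4 is therefore estimated at 5000 nM, with a range from 2000 nM to 15000 nM.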

Compound 4, half-maximal inhibitory concentration: 270000 nM
For compound 4 the middle estimate is 54-fold (1.73 log units) below the measured one; the whole stated range lies below it.
By their numbers in this assay, from the lowest: compound 3; then compound 2; then compound 1; then compound 4.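

On the saturated chain carbon bound to a sulfur, where the chlorine sits on the benzyl ring matters far more than the first pair suggested: in this assay there is a 90-fold higher number from compound 3 to compound 4 (1.95 log units; beyond the scatter) and a 34-fold higher number from compound 2 to compound 4 (1.53 log units; beyond the scatter), both much larger than a 2.7-fold lower number from compound 2 to compound 3 (0.43 log units; beyond the scatter). Chlorine on this ring also no longer goes with a lower number than methyl across the set, since 3-chlorophenyl and 4-chlorophenyl fit that pattern but 2-chlorophenyl goes against it, with a 4.4-fold higher number from compound 1 to compound 4 (0.64 log units; beyond the scatter). The groups in compound 3 and compound 4 have the same atoms and the same counts, so the large step follows a shift of the chlorine alone, and no measurement available here explains it.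

The compounds shown leave open whether this sharp rise belongs to chlorine itself or would also appear with another group in the same ring position, such as 2-fluorophenyl, 2-methylphenyl or 2-methoxyphenyl. They also leave open how an unsubstituted benzyl group would compare with the three chlorobenzyl groups, which would show whether each chlorine position lowers or raises the number relative to having no substituent.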